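The compounds below may be only part of what the source reports. "The series", "measured", "known", "first", "only" and "open" are said of these compounds alone.

Measured in an ADME assay on K562 cells (Homo sapiens) for cytotoxicity, with a stated time of 72 h; a lower number here means a stronger inhibitor, a higher number a weaker inhibitor:
- Compound 1 `COc1ccc(CNc2ncnc3c2ncn3C2CCCCO2)c(OC)c1`: > 25000 nM, a limit
- Compound 2 `Oc1cccc(CNc2ncnc3c2ncn3C2CCCCO2)c1O`: 92000 nM
- Compound 3 `COc1ccc(CNc2ncnc3c2ncn3C2CCCCO2)c(OC)c1OC`: > 37500 nM, a limit

Compound 3 has no exact number, only (the limit of > 37500 nM in this assay, at which 1 of the 3 values shown sits). Compound 1 also has no exact number, only (the limit of > 25000 nM in this assay, at which 1 of the 3 values shown sits). Of the three, only compound 2 gives a true value.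

Compound 4 `COc1ccc(CNc2ncnc3c2ncn3C2CCCO2)c(OC)c1OC` differs from compound 3 in one group: oxolan-2-yl in place of oxan-2-yl on an aromatic nitrogen. In words, it carries oxolan-2-yl in place of oxan-2-yl on an aromatic nitrogen.

For the measured compounds named here, the only measured step is a step that the two limits leave unreadable from compound 1 to compound 3. It concerns methoxy in place of hydrogen on an aromatic carbon, a different change at a different place, and its size cannot be read. Going by the values given here, no measured step therefore tests this ring swap, and no step beyond the usual scatter is expected in this assay. Among the compounds with values here, compound 4 is expected to remain as weak as the series so far, where compound 2 gives 92000 nM. The expected step is a step that the limit leaves unreadable from compound 3 to compound 4. Compound 4 is estimated at 60000 nM, with an expected range of 25000 nM to 150000 nM.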

Compound 4, half-maximal inhibitory concentration: > 100000 nM
Compound 4: only a limit was reported; the forecaster's own chance of this, stated with the estimate: 60%; at least 1.6-fold (0.22 log units) between middle value and limit.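

Compound 3 and compound 4 are each reported only as a limit in this assay, and the step between them cannot be read. The compounds shown leave open whether oxolan-2-yl in place of oxan-2-yl on an aromatic nitrogen changes the half-maximal inhibitory concentration at all.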